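The compounds below may be only part of what the source reports. "The series", "measured", "known", "first", "only" and "open" are said of these compounds alone.

Measured compounds:
compound 1 `Cc1cc(NCCN(C)C)nc2ccc(NC(=O)c3ccc(Cl)c(Cl)c3)cc12` — 6670 nM
compound 2 `CCN1CCN(c2cc(C)c3cc(NC(=O)c4ccccc4C)ccc3n2)CC1` — 29200 nM
compound 3 `CCN1CCN(c2cc(C)c3cc(NC(=O)c4ccc(OC)cc4)ccc3n2)CC1` — 9000 nM

All three numbers come from a functional assay on SK-BR-3 cells (Homo sapiens) for antiproliferative activity, read by MTT assay, with a stated time of 72 h; a higher number here means a weaker inhibitor, a lower number a stronger inhibitor. Compound 3 stands second highest of the three: compound 1 lies within the scatter of it, while compound 2 sits beyond the scatter on the higher side. Compound 4 `CCN1CCN(c2cc(C)c3cc(NC(=O)c4cccc(C)c4)ccc3n2)CC1` differs from compound 3 by 3-methylphenyl in place of 4-methoxyphenyl on a carbonyl carbon. Among the compounds with values here, the only step at this carbonyl carbon is a 3.2-fold lower number from compound 2 to compound 3 (0.51 log units; beyond the scatter), going from 2-methylphenyl to 4-methoxyphenyl; compound 4 returns to a methylphenyl, now 3-methylphenyl, for which no step exists. Expected in this assay is a modest rise, a 1.7-fold higher number from compound 3 to compound 4 (0.22 log units; within the scatter), kept short of the earlier step because compound 2 gave 29200 nM with a different methylphenyl. Compound 4 is therefore estimated at 15000 nM, range 6000 nM to 40000 nM.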

Compound 4, half-maximal inhibitory concentration: 13700 nM
Compound 4: the middle estimate sits 1.1-fold (0.04 log units) above what was measured; the measured number falls inside the stated range.
By their numbers in this assay, from the lowest: compounds 1, 3 and 4 (each within the scatter of the next, the first and the last beyond it); then compound 2.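

In this assay, 3-methylphenyl in place of 2-methylphenyl on the carbonyl carbon gives a 2.1-fold lower number from compound 2 to compound 4 (0.33 log units; beyond the scatter), so the two methylphenyl groups are not interchangeable at this position. By contrast, 3-methylphenyl in place of 4-methoxyphenyl gives a 1.5-fold higher number from compound 3 to compound 4 (0.18 log units; within the scatter), which leaves compound 3 and compound 4 unseparated. No available evidence explains the gap between the two methylphenyl groups.

Still open, as far as these compounds go, is how 4-methylphenyl or 2-methoxyphenyl would read on this carbonyl carbon, which would separate the effect of the group from that of its place on the ring. From the compounds shown here alone, a phenyl carrying an amine or a carboxylic acid also remains open.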